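From 4-aminophenyl to 2-chlorophenyl on the shared core

This account rests on a few compounds, and the source may have more. Where it says the series, first, only, none or still open, it means among the compounds named here.

Going by the values given here, in a functional assay on SGC-7901 cells (Homo sapiens) for cytotoxicity, read by MTT assay, with a stated time of 48 h (on this read-out lower numbers stand for stronger inhibition and higher numbers for weaker inhibition), compound 1 `Cc1ncc([N+](=O)[O-])n1CCSc1nnc(-c2ccc(N)cc2)o1` gives 31700 nM and holds the higher of the two numbers so far, while compound 2 `CCOc1ccc(-c2nnc(SCCn3c([N+](=O)[O-])cnc3C)o2)cc1` gives 14100 nM as the only other measurement. Compound 3 `Cc1ncc([N+](=O)[O-])n1CCSc1nnc(-c2ccccc2Cl)o1` differs from compound 1 by 2-chlorophenyl in place of 4-aminophenyl on an aromatic carbon on the shared core. Among the compounds with values here, the one measured step that bears on this is the modest 2.2-fold lower number from compound 1 to compound 2 (0.35 log units; beyond the scatter) for ethoxy in place of amino on an aromatic carbon. A similarly modest move in the same direction is therefore expected in this assay as an estimated 1.9-fold lower number from compound 1 to compound 3 (0.27 log units; within the scatter) for this change. Compound 3 is estimated at 17000 nM with an expected range from 6000 nM to 40000 nM in this test.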

Compound 3, half-maximal inhibitory concentration: 32600 nM
Compound 3: middle estimate off by 1.9-fold (0.28 log units), on the low side; measured number inside the range.
By their numbers in this assay, from the lowest: compound 2; then compounds 1 and 3 (each within the scatter of the next).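

In this assay, replacing 4-aminophenyl with 2-chlorophenyl on the shared core gives a 1.0-fold higher number from compound 1 to compound 3 (0.01 log units; within the scatter). Removing the 4-aminophenyl group at this position therefore does not by itself bring the lower number seen in the other measured change, a 2.2-fold lower number from compound 1 to compound 2 (0.35 log units; beyond the scatter); what enters matters, at least for these two replacements. No measurement available here accounts for this difference between the two replacements. Still open, as far as these compounds go, is how a nitrile or a carboxylic acid on the phenyl ring would read in this assay.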